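Swapping Methoxy for Dimethylamino in a Fluorophenyl Chalcone Series

The compounds below may be only part of what the source reports. "The series", "measured", "known", "first", "only" and "open" are said of these compounds alone.

Three compounds have been measured so far in a functional assay on HCT-8 cells (Homo sapiens) for antiproliferative activity, read by sulforhodamine B assay, with a stated time of 48 h; a lower number here means a stronger inhibitor, a higher number a weaker inhibitor:

- compound 1 `COc1ccc(/C=C/C(=O)c2ccccc2-c2ccc(F)cc2)cc1` gives 220 nM
- compound 2 `COc1ccc(/C=C/C(=O)c2ccccc2-c2ccc(F)cc2)cc1O` gives 38 nM
- compound 3 `COc1ccc(/C=C/C(=O)c2ccccc2-c2ccc(F)cc2)cc1B(O)O` gives 63 nM

Compound 1 has the highest number of the three, which makes it the weakest inhibitor in this small set. Both other compounds lie beyond the scatter from it, with a 5.8-fold lower number from compound 1 to compound 2 (0.76 log units; beyond the scatter) and a 3.5-fold lower number from compound 1 to compound 3 (0.54 log units; beyond the scatter). Between the two of them, a 1.7-fold higher number from compound 2 to compound 3 (0.22 log units; within the scatter) stays within the scatter.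

Compound 4 `CN(C)c1ccc(/C=C/C(=O)c2ccccc2-c2ccc(F)cc2)cc1` has not yet been measured. It departs from compound 1 by dimethylamino in place of methoxy on an aromatic carbon, with dimethylamino in place of methoxy on an aromatic carbon, para to a large group.

The measured steps offer only indirect guidance. Within the data shown here, both modest gains come from adding a group while keeping the methoxy, whereas compound 4 loses that methoxy, and no measured compound carries dimethylamino. The data therefore give no direction for this replacement, and the best anchor is compound 1 at 220 nM with a wide margin on either side. The expected change is a 1.1-fold higher number from compound 1 to compound 4 (0.04 log units; within the scatter), so no shift beyond the scatter is anticipated. For compound 4 the estimated value is 240 nM, with an expected range of 70 nM to 800 nM.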

Compound 4, half-maximal inhibitory concentration: 130 nM
Estimate against measurement, compound 4: 1.8-fold (0.27 log units) above; the measured number falls inside the stated range.
By their numbers in this assay, from the lowest: compounds 2 and 3 (each within the scatter of the next); then compounds 4 and 1 (each within the scatter of the next).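

In this assay, among these compounds, dimethylamino in place of methoxy gives a 1.7-fold lower number from compound 1 to compound 4 (0.23 log units; within the scatter), which is the first reading at this place on the ring, since compounds 1, 2 and 3 all keep the methoxy. The step shows that, on an aromatic carbon para to a large group, the methoxy of compound 1 can give way to dimethylamino without a shift beyond the scatter, so within this pair the methoxy oxygen is not needed to hold the activity in this range. No measurement is available that would explain why the two groups fall within the scatter of each other.

The compounds shown leave open whether other groups at this place, such as methylamino, an unsubstituted amine or a longer chain like ethoxy, would also stay within the scatter of compound 1 or move beyond it. They also leave open whether the hydroxy of compound 2 or the boron-bearing group of compound 3 would have a similar effect on the core of compound 4, which carries dimethylamino instead of methoxy.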